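Pivalamide in place of methyl carbamate on compound 3

This account rests on a few compounds, and the source may have more. Where it says the series, first, only, none or still open, it means among the compounds named here.

Measured compounds:
compound 1 `CCOC(=O)c1cccc(-c2ccc(O)cc2)c1`: 77%
compound 2 `CCOC(=O)c1cccc(-c2ccc3c(c2)CCN3)c1`: 66%
compound 3 `COC(=O)Nc1cccc(-c2ccc(N(C)C)cc2)c1`: 95%

In an assay on COS-7 cells for inhibition of patatin-like phospholipase domain-containing protein 2 (Mus musculus), tested at 200 uM (on this read-out higher numbers stand for more inhibition at the one concentration tested (going by the name of the read-out) and lower numbers for less inhibition), compound 3 gives 95%, the highest of the three numbers. Compound 1 stands nearest, and in this assay compound 1 gives 77%, a gap beyond the scatter. Compound 2 stands furthest, and in this assay compound 2 gives 66%, also beyond the scatter. Going by the values given here, none of these three pairs differ in a single place, so no step among them can be read as the effect of one change.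

Compound 4 `CN(C)c1ccc(-c2cccc(NC(=O)C(C)(C)C)c2)cc1` has not yet been tested in this assay. It differs from compound 3 in one place: tert-butyl in place of methoxy on a carbonyl carbon. Among the compounds with values here, no measured pair shows this change, so the size of its step rests on no precedent. Because compound 3 already gives 95%, little room remains above it, and the expected step from a number 10 percentage points lower from compound 3 to compound 4 (within the scatter) is a small decrease that may stay within the scatter. For compound 4 the estimate is 85%, with a range from 60% to 98%.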

Compound 4, a percentage reported as inhibition, at one concentration (the size of the read-out at that concentration, not a potency): 25%
Compound 4: the middle estimate sits 60 percentage points above what was measured; measured number below the stated range.
By their numbers in this assay, from the lowest: compound 4; then compound 2; then compound 1; then compound 3.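

In this assay, replacing methoxy with tert-butyl on a carbonyl carbon whose other neighbour is an amide-type nitrogen gives a number 70 percentage points lower from compound 3 to compound 4 (beyond the scatter). This is the first comparison among these compounds that isolates a single place, and it shows that the group on this carbonyl carbon can by itself largely set the inhibition seen at the one concentration tested. Nothing measured here explains the size of this step.

As far as these compounds go, with only methoxy and tert-butyl compared at this place, it remains open whether the inhibition depends on the oxygen attached to the carbonyl carbon or on the carbon groups that replace it. An ethoxy, methyl or dimethylamino group on the same carbon could help separate these possibilities, showing whether the number stays near that of compound 3 or falls toward that of compound 4.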